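The source may report more compounds than this note shows. Statements on the series, on what has been measured and on what is new or still open speak of the compounds shown alone.

Compound 1 `Cc1ccsc1CN[C@@H]1C[C@H]2C[C@@H]([C@H]1C)C2(C)C` gives 10000 nM in an ADME assay on MDCK cells (Canis lupus familiaris) for cytotoxicity, read by microscopy, with a stated time of 48 h; on this read-out higher numbers stand for lower toxicity in this test and lower numbers for higher toxicity in this test. Compound 2 `C[C@H]1[C@H](NCc2ccc(Br)s2)C[C@H]2C[C@@H]1C2(C)C` gives 43000 nM in this assay.

Compound 2 holds the highest of the two numbers measured; its nearest neighbour is compound 1, which sits a modest distance below it, as a 4.3-fold higher number from compound 1 to compound 2 (0.63 log units; beyond the scatter) shows. Compound 3 `C[C@H]1[C@H](NCc2cnccn2)C[C@H]2C[C@@H]1C2(C)C` is the next, unmeasured compound. The change is pyrazin-2-yl in place of 5-bromothiophen-2-yl on a saturated chain carbon bound to an amine nitrogen. Among the compounds with values here, only the step from compound 1 to compound 2 bears on it, and that step also swapped one aromatic group for another at the same place; it was modest and beyond the scatter. A change of similar size, in either direction, is therefore expected, with a move back toward compound 1 slightly favoured, giving an estimated 1.7-fold lower number from compound 2 to compound 3 (0.24 log units; within the scatter). Compound 3 is expected to give about 25000 nM, within 7000 nM to 90000 nM.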

Compound 3, minimum cytotoxic concentration: > 100000 nM
Compound 3 was reported as a limit; the forecaster's own chance of this, stated with the estimate: 25%; at least 4.0-fold (0.60 log units) between middle value and limit.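

In this assay compound 3 gives > 100000 nM, which is a limit and not a number: the limit of > 100000 nM in this assay, at which 1 of the 3 values shown sits.

The read-out at this place therefore moves further than the earlier step showed, with pyrazin-2-yl giving an at least 2.3-fold higher number from compound 2 to compound 3 (0.36 log units; beyond the scatter). Measured against 3-methylthiophen-2-yl, the same group gives an at least 10-fold higher number from compound 1 to compound 3 (1.00 log units; beyond the scatter), so among these three compounds it goes with the lowest toxicity in this test.

From the compounds shown here alone, how far the true value of compound 3 lies beyond its limit remains open. Also open, going by these compounds, is whether a phenyl or pyridin-2-yl group at this place would behave like pyrazin-2-yl or like the thiophene groups.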